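Methyl on the anilino ring of a chalcone-like thiazole series

A few compounds are considered here, and "the series" means these few. Any claim that something is new, unique, unknown or untested is made for them only; others in the source may bear on it.

Measured compounds:
Compound 1 `Cc1cccc(Nc2nc(C)c(C(=O)/C=C/c3ccccc3Cl)s2)c1` — in a functional assay on Bel-7402 cells (Homo sapiens) for cytotoxicity, read by MTT assay (a lower number here means a stronger inhibitor, a higher number a weaker inhibitor), compound 1 gives > 25000 nM, which is a limit of the assay.
Compound 2 `Cc1ccc(Nc2nc(C)c(C(=O)/C=C/c3ccc(Cl)cc3)s2)cc1` — in this assay compound 2 gives > 25000 nM, again a limit.
Compound 3 `Cc1nc(Nc2ccccc2)sc1C(=O)/C=C/c1ccccc1Cl` — in this assay compound 3 gives > 25000 nM, also a limit.

Compound 3 therefore stands at the same limit as both other measured compounds; no number separates them, and the limit of > 25000 nM in this assay, at which 3 of the 3 values shown sit, is where every value sits. Among the measured compounds shown here, the one step between measured compounds that differ in a single place, a step that the two limits leave unreadable from compound 1 to compound 3, cannot be read in size, since both ends are limits.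

Compound 4 `Cc1ccc(Nc2nc(C)c(C(=O)/C=C/c3ccccc3Cl)s2)cc1` differs from compound 3 by methyl in place of hydrogen on an aromatic carbon. For the measured compounds named here, the only measured step bearing on this kind of change is the one from compound 1 to compound 3, and it is unreadable; compound 2 carries the same methyl on its anilino ring and also sits at the limit. The evidence thus gives no direction, and the expected step that the limit leaves unreadable from compound 3 to compound 4 is none beyond the scatter. Compound 4 is accordingly expected to remain at or beyond the limit, with an estimate of 40000 nM and a range from 15000 nM to 150000 nM.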

Compound 4, half-maximal inhibitory concentration: > 25000 nM
Compound 4: only a limit was reported; the forecaster's own chance of this, stated with the estimate: 85%; the middle value is on the limit's open side.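

In this assay, among the compounds shown here, compound 4 gives > 25000 nM as a limit of the assay, so no step from compound 1, compound 2 or compound 3 to compound 4 can be read in size. All four compounds share one value: the limit of > 25000 nM in this assay, at which 4 of the 4 values shown sit. The compounds shown leave open whether moving the chloro or methyl group, or adding the methyl, changes cytotoxicity at all.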